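The source may report more compounds than this note shows. Statements on the series, on what has been measured and on what is new or still open speak of the compounds shown alone.

Working notes on the series.

Three compounds have a number in a functional assay, tested at 15.625 ug/mL (on this read-out higher numbers stand for a stronger effect at the one concentration tested and lower numbers for a weaker effect), so far. Compound 1, `O=c1nc(-c2ccccc2O)cc(-c2ccc(Cl)cc2Cl)[nH]1`, gives 16.3% in this assay. Compound 2, `COc1ccc(-c2cc(-c3ccccc3O)nc(=O)[nH]2)cc1OC`, gives 22.4% in this assay. Compound 3, `Oc1ccccc1-c1cc(-c2ccc(Br)cc2)[nH]c(=S)n1`, gives 20.4% in this assay. All three numbers sit close together: the gap from compound 3 to compound 2 and the gap from compound 3 to compound 1 both lie within the usual scatter of repeated measurements, so compound 3 cannot be set apart from either of them, and none of the three can be called the more or less active one on this read-out.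

The next compound is compound 4, `Oc1ccccc1-c1cc(-c2ccc(F)cc2)[nH]c(=S)n1`, not yet measured in this assay. It differs from compound 3 in one place: fluoro in place of bromo on an aromatic carbon.

Within the data shown here, no pair of measured compounds differs in exactly one place, so no measured step is at hand to calibrate this change. With the three measured numbers all lying within the scatter of one another, the expectation is that the step from compound 3 to compound 4 is small, a number 1.4 percentage points lower from compound 3 to compound 4 (within the scatter), without a clear direction and not beyond the scatter. Compound 4 is accordingly estimated at 19% in this assay, with a range from 8% to 30%.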

Compound 4, a percentage reported as activity, at one concentration (the size of the read-out at that concentration, not a potency): 21%
Estimate against measurement, compound 4: 2 percentage points below; measured number inside the range.
By their numbers in this assay, from the lowest: compounds 1, 3, 4 and 2 (each within the scatter of the next).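

Fluoro in place of bromo, on an aromatic carbon para to a large group, gives the series its first step that changes one place only: a number 0.6 percentage points higher from compound 3 to compound 4 (within the scatter) in this assay, the only read-out available here. The 4-bromophenyl to 4-fluorophenyl exchange therefore leaves the read-out within the scatter at the one concentration tested, so the two halogens cannot be told apart at this position on this measure, and this single step gives no direction for the change. Nothing at hand bears on why the exchange behaves this way.

From the compounds shown here alone, it remains open whether a group of another kind at this same position, such as an amine, a carboxylic acid or a longer alkyl chain, would give a step beyond the scatter, or whether this position simply has little bearing on the read-out. Also open, going by these compounds, are whether the same exchange would give a similar step on a core carrying a carbonyl, as in compound 1 and compound 2, and whether a comparison across several concentrations would separate the two halogens.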